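A few compounds are considered here, and "the series" means these few. Any claim that something is new, unique, unknown or untested is made for them only; others in the source may bear on it.

Working notes on the series. Compound 1 `CC(=O)c1c(Nc2ccc(F)cc2F)[nH]c2c(Cl)cc(Cl)c(Cl)c2c1=O` carries an acetyl group. In an ADME assay on Vero cells (Chlorocebus sabaeus) for cytotoxicity (a higher number here means that more compound is tolerated, a lower number that less compound is tolerated), compound 1 gives > 25000 nM, which is a limit and not a number. Compound 2 `CC(=O)c1c(Nc2ccc(F)c(F)c2F)[nH]c2c(F)cc(F)cc2c1=O` gives > 25000 nM, also a limit. Compound 1 thus stands at the limit of > 25000 nM in this assay, at which 2 of the 3 values shown sit. Compound 3 `CC(C)C(=O)c1c(Nc2ccc(F)c(F)c2F)[nH]c2c(Cl)ccc(Cl)c2c1=O` bears isopropyl on a carbonyl carbon and gives a true number, 10900 nM. Compound 4 `CC(C)C(=O)c1c(Nc2ccc(F)cc2F)[nH]c2c(Cl)cc(Cl)c(Cl)c2c1=O` departs from compound 1 by one change: isopropyl in place of methyl on a carbonyl carbon. For the measured compounds named here, no measured pair isolates this change, so the expectation rests on compound 3 alone, at 10900 nM. A modest fall in the tolerated concentration is expected in this assay, with an estimated step of an at least 1.9-fold lower number from compound 1 to compound 4 (0.28 log units; that floor lies within the scatter). Compound 4 is estimated at 13000 nM, with an expected range of 5500 nM to 28000 nM.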

Compound 4, half-maximal cytotoxic concentration: > 25000 nM
Compound 4 was reported as a limit (the forecaster's own chance of this, stated with the estimate: 25%); middle value at least 1.9-fold (0.28 log units) from the limit.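

Compound 1 and compound 4 both stand at a limit in this assay, so the step between them cannot be read. The compounds shown leave open whether isopropyl in place of methyl on a carbonyl carbon changes the tolerated concentration at all.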